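A few compounds are considered here, and "the series" means these few. Any claim that something is new, unique, unknown or untested is made for them only; others in the source may bear on it.

The measured compounds:

Compound 1, `Brc1ccccc1COc1nc2ccccc2s1`; in a functional assay on the whole organism with Mus musculus as the target, with a stated time of 1 h, at a dose of 100 mg/kg by the intraperitoneal route (on this read-out higher numbers stand for more inhibition at the one dose given (going by the name of the read-out) and lower numbers for less inhibition), compound 1 gives 75.6%.
Compound 2, `Brc1cccc(COc2nc3ccccc3s2)c1`; in this assay compound 2 gives 77.6%.
Compound 3, `Clc1ccccc1COc1nc2ccccc2s1`; in this assay compound 3 gives 14.6%.

Compound 1 and compound 2 are built from the same atoms joined differently; the difference between the two cores is not broken down here, and their two values lie within the scatter of each other. Going by the values given here, the one step measured in this set is the change (chloro in place of bromo on an aromatic carbon), which gives a number 61 percentage points lower from compound 1 to compound 3 (beyond the scatter).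

Compound 4, `Clc1cccc(COc2nc3ccccc3s2)c1`, has not yet been measured. It differs from compound 2 by chloro in place of bromo on an aromatic carbon. Among the compounds with values here, this is the same kind of change as the one from compound 1 to compound 3, but not the same: in compound 3 the chloro sits ortho to a large group, in compound 4 meta to a large group. Resting on the step from compound 1 to compound 3, a number 61 percentage points lower from compound 1 to compound 3 (beyond the scatter), a step of a number 47.6 percentage points lower from compound 2 to compound 4 (beyond the scatter) is expected from compound 2 to compound 4, with wide uncertainty since that step was seen only once and at a different place. For compound 4 the estimated value in this assay is 30%, expected to lie between 8% and 65%.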

Compound 4, a percentage reported as inhibition, in the whole organism at one dose (the size of the read-out at that dose, not a potency): 80%
For compound 4 the middle estimate is 50 percentage points below the measured one, outside the stated range (above it).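

In this assay, chloro in place of bromo gives a number 2.4 percentage points higher from compound 2 to compound 4 (within the scatter) and so, on this core, a step that stays inside the scatter. Set beside the earlier step, the same change does not carry over from one core to the other: the same change on two cores in this assay, a number 61 percentage points lower (beyond the scatter) from compound 1 to compound 3 and a number 2.4 percentage points higher (within the scatter) from compound 2 to compound 4, 63.4 percentage points apart, beyond the scatter of two such steps. This shows that the large loss seen with compound 3 cannot be read as a general result of this change in the series, but two steps do not show what sets them apart or how the change would behave on any further core, and a read-out at a single dose is not a potency.

The compounds shown carry only bromo and chloro on the six-membered aromatic ring of carbon only. They leave open how the read-out would respond to a fluoro, methyl or methoxy group in those places, or to an amine or a carboxylic acid there.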